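Swapping Trifluoromethyl for Ethoxycarbonyl on the Aryl Ring

The compounds below may be only part of what the source reports. "The series", "measured", "known", "first", "only" and "open" are said of these compounds alone.

compound 1 `CC(C)(C)c1ccc(-c2cc(N3CCC(CNS(N)(=O)=O)CC3)ncn2)cc1`: 19700 nM
compound 2 `NS(=O)(=O)NCC1CCN(c2cc(-c3ccc(C(F)(F)F)cc3)ncn2)CC1`: 22500 nM

Among the compounds with values here, in a functional assay on MCF7 cells (Homo sapiens) for antiproliferative activity, read by sulforhodamine B assay, with a stated time of 48 h (a higher number here means a weaker inhibitor of growth, a lower number a stronger inhibitor of growth), compound 2 gives 22500 nM; the only other number, that of compound 1 at 19700 nM, lies within the scatter of it, as the single measured step of a 1.1-fold higher number from compound 1 to compound 2 (0.06 log units; within the scatter) shows. Compound 3 `CCOC(=O)c1ccc(-c2cc(N3CCC(CNS(N)(=O)=O)CC3)ncn2)cc1` differs from compound 2 in one place: ethoxycarbonyl in place of trifluoromethyl on an aromatic carbon. Within the data shown here, no measured step involves an ethoxycarbonyl, and the one change made at this aromatic carbon left the number within the scatter, so no step beyond the scatter is expected here either. For compound 3 the estimated value is 21000 nM, between 8000 nM and 55000 nM. That amounts to an expected step of a 1.1-fold lower number from compound 2 to compound 3 (0.03 log units; within the scatter).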

Compound 3, concentration for 50% growth inhibition: 4100 nM
Estimate against measurement, compound 3: 5.1-fold (0.71 log units) above, outside the stated range (below it).
By their numbers in this assay, from the lowest: compound 3; then compounds 1 and 2 (each within the scatter of the next).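

In this assay ethoxycarbonyl on this aromatic carbon brings a 5.5-fold lower number from compound 2 to compound 3 (0.74 log units; beyond the scatter) and also a 4.8-fold lower number from compound 1 to compound 3 (0.68 log units; beyond the scatter). The swap between tert-butyl and trifluoromethyl had stayed within the scatter, so this carbon now proves not to be indifferent to what it carries. Nothing available here explains the stronger growth inhibition. As far as these compounds go, whether the carbonyl, the ethyl part or the whole ethoxycarbonyl group matters remains open. A carboxylic acid or an amide on the same carbon would help to separate these possibilities.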